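Anilino in place of aminopiperidinyl at a tolerant position

A few compounds are considered here, and "the series" means these few. Any claim that something is new, unique, unknown or untested is made for them only; others in the source may bear on it.

Compound 1 `Cc1cc(C2CCC2)c(S(C)(=O)=O)cc1C(=O)N=C(N)N` gives 8.2 nM in a functional assay for inhibition of sodium/hydrogen exchanger (Oryctolagus cuniculus); a lower number here means a stronger inhibitor, a higher number a weaker inhibitor.
Compound 2 `Cc1cc(N2CCC(N)CC2)c(S(C)(=O)=O)cc1C(=O)N=C(N)N` gives 9.8 nM.
Compound 3 `Cc1cc(Nc2ccccc2)c(S(C)(=O)=O)cc1C(=O)N=C(N)N` is not yet measured.

Compound 2 holds the higher of the two numbers shown, yet the step of a 1.2-fold higher number from compound 1 to compound 2 (0.08 log units; within the scatter) is within the scatter, so compound 2 and compound 1 cannot be told apart. Compound 3 differs from compound 2 by anilino in place of 4-aminopiperidin-1-yl on an aromatic carbon. Among the compounds with values here, the only measured step at this position, a 1.2-fold higher number from compound 1 to compound 2 (0.08 log units; within the scatter), stayed within the scatter, so no step beyond the scatter is expected here; the expected step is a 1.4-fold higher number from compound 2 to compound 3 (0.15 log units; within the scatter). Compound 3 is estimated at 14 nM, with a range from 4 nM to 50 nM.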

Compound 3, half-maximal inhibitory concentration: 21 nM
The estimate for compound 3 lay 1.5-fold (0.18 log units) below the measured number, within the range that was stated.
By their numbers in this assay, from the lowest: compounds 1 and 2 (each within the scatter of the next); then compound 3.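

In this assay, the position ortho to a methylsulfonyl group proves not to be indifferent to its substituent: anilino gives a 2.1-fold higher number from compound 2 to compound 3 (0.33 log units; beyond the scatter) and a 2.6-fold higher number from compound 1 to compound 3 (0.41 log units; beyond the scatter), whereas cyclobutyl and 4-aminopiperidin-1-yl could not be told apart. Both steps are modest, so the three groups still span a narrow range. Nothing available accounts for this difference.

As far as these compounds go, it remains open whether cyclohexylamino, which keeps the nitrogen link but has a non-aromatic ring, would fall with compound 3 or with compound 1 and compound 2. From the compounds shown here alone, how a carboxylic acid or an amine on the anilino ring would shift the number also remains open.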